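The source may hold more compounds than are shown below. What is called first, only, known or untested is meant among the compounds shown, and "the series" means these compounds.

Of the compounds shown here, three sharing one core have been measured in a functional assay on HCT-116 cells (Homo sapiens) for inhibition, read by sulforhodamine B assay, with a stated time of 48 h, tested at 50 uM; on this read-out lower numbers stand for less inhibition of growth and higher numbers for more inhibition of growth at the one concentration tested. Compound 1 `CCOc1ccc([C@@H]2CC(=O)c3cc(CC=C(C)C)c(OC)cc3O2)cc1` gives 65%. Compound 2 `COc1cc2c(cc1CC=C(C)C)C(=O)C[C@@H](c1ccc(Oc3ccc(F)cc3)cc1)O2` gives 29%, and compound 3 `COc1ccc([C@@H]2C/C(=N/OCc3cn(-c4cccc(CO)c4)nn3)c3cc(CC=C(C)C)c(OC)cc3O2)cc1` gives 27%. On these numbers compound 2 stands second highest of three, within the scatter of compound 3 and far below compound 1. Among the compounds with values here, the only measured step, a number 36 percentage points lower from compound 1 to compound 2 (beyond the scatter), came with 4-fluorophenyl in place of ethyl on an oxygen on an aromatic ring. Compound 4 `COc1ccc([C@@H]2CC(=O)c3cc(CC=C(C)C)c(OC)cc3O2)cc1` differs from compound 2 by methyl in place of 4-fluorophenyl on an oxygen on an aromatic ring, which runs that step in reverse. Because the measured step of a number 36 percentage points lower from compound 1 to compound 2 (beyond the scatter) was large, a rise in this assay is expected, a number 26 percentage points higher from compound 2 to compound 4 (beyond the scatter). Compound 4 is thus estimated at 55%, with a range from 35% to 75%.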

Compound 4, percent growth inhibition at one concentration: 68%
Estimate against measurement, compound 4: 13 percentage points below, within the range that was stated.
By their numbers in this assay, from the lowest: compounds 3 and 2 (each within the scatter of the next); then compounds 1 and 4 (each within the scatter of the next).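

With 4-fluorophenyl on the oxygen, growth inhibition is low on both comparisons: methyl in its place gives a number 39 percentage points higher from compound 2 to compound 4 (beyond the scatter), matching the earlier loss seen against ethyl. The two alkyl groups do not separate, as hydrogen in place of methyl on a saturated chain carbon bound to an oxygen on an aromatic ring gives a number 3 percentage points higher from compound 1 to compound 4 (within the scatter). Nothing measured here accounts for either step. On these data alone, whether a longer chain such as butyl, a benzyl group or an unsubstituted phenyl on this oxygen would read like ethyl and methyl or like 4-fluorophenyl remains open.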